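Selenium for sulfur on the shared core: cytotoxicity notes

The compounds below may be only part of what the source reports. "The series", "measured", "known", "first", "only" and "open" are said of these compounds alone.

Measured so far:
compound 1 `CS/C(=N\C(=O)c1sccc1Cl)NC(=O)c1sccc1Cl` gives > 100000 nM
compound 2 `C[Se]/C(=N\C(=O)c1ccco1)NC(=O)c1ccco1` gives > 100000 nM
compound 3 `CS/C(=N\C(=O)c1cc(-c2ccccc2)nc2ccccc12)NC(=O)c1cc(-c2ccccc2)nc2ccccc12` gives > 100000 nM

All three values come from a functional assay on HepG2 cells (Homo sapiens) for cytotoxicity, read by MTT assay, with a stated time of 72 h; on this read-out lower numbers stand for higher toxicity in this test and higher numbers for lower toxicity in this test. For compound 1 the value is a limit of the assay, not a number. The same holds for compound 2 and for compound 3, each reported only as a limit. Among the compounds with values here, the whole set therefore sits at the limit of > 100000 nM in this assay, at which 3 of the 3 values shown sit, and no step between two measured compounds can be sized.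

Compound 4 `C[Se]/C(=N\C(=O)c1sccc1Cl)NC(=O)c1sccc1Cl` is the next member. Relative to compound 1 the change is a group of 2 heavy atoms (1 carbon, 1 selenium; no ring) in place of a group of 2 heavy atoms (1 carbon, 1 sulfur; no ring), on a carbon with a double bond to nitrogen. Compound 2 already carries the same entering group on its own carbon with a double bond to nitrogen and is reported only as a limit in this assay. Within the data shown here, with compound 1 at the limit and no measured step to lean on, the expected step from compound 1 to compound 4 is none beyond the scatter a step that the limit leaves unreadable from compound 1 to compound 4. Compound 4 is expected to give 150000 nM, with a range of 50000 nM to 500000 nM, most probably reported again only as a limit.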

Compound 4, concentration lethal to 50% of the cells: 8670 nM
For compound 4 the middle estimate is 17-fold (1.24 log units) above the measured one; measured number outside the range, below it.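

Putting the selenium-bearing group in place of methylsulfanyl, on a carbon with a double bond to nitrogen, gives in this assay an at least 11-fold lower number from compound 1 to compound 4 (1.06 log units; beyond the scatter), so a change at this one place is enough to bring the value off the limit. The earlier compounds shown here showed no readable value at all: the limit of > 100000 nM in this assay, at which 3 of the 4 values shown sit. Compound 1 enters this step only as a limit, so the printed size is a floor and not a measured gap.

Compound 2 also carries the selenium-bearing group and is reported only as a limit, > 100000 nM, so the compounds shown do not settle whether the step holds with other groups on the shared core. Also open, going by these compounds, is what a longer chain or an amine would give at this same place.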